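A few compounds are considered here, and "the series" means these few. Any claim that something is new, unique, unknown or untested is made for them only; others in the source may bear on it.

Measured so far in an ADME assay on Vero cells (Chlorocebus sabaeus) for cytotoxicity; a higher number here means that more compound is tolerated, a lower number that less compound is tolerated:
compound 1 `C[C@]1(CO)O[C@@H](n2cc(I)c3c(N)ncnc32)[C@H](O)[C@@H]1O` gives 8080 nM.
compound 2 `C[C@]1(CO)O[C@@H](n2cc(-c3cccs3)c3c(N)ncnc32)[C@H](O)[C@@H]1O` gives > 50000 nM, which is a limit of the assay and not a number (the limit of > 50000 nM in this assay, at which 1 of the 2 values shown sits).

Compound 2 therefore stands at the upper end of what has been measured here, since the step of an at least 6.1-fold higher number from compound 1 to compound 2 (0.79 log units; beyond the scatter) is known only as a lower bound and not as a settled size. Compound 3 `C[C@]1(CO)O[C@@H](n2cc(-c3cc4ccccc4o3)c3c(N)ncnc32)[C@H](O)[C@@H]1O` differs from compound 2 by 1-benzofuran-2-yl in place of thiophen-2-yl on an aromatic carbon. Among the measured compounds shown here, the only measured step, an at least 6.1-fold higher number from compound 1 to compound 2 (0.79 log units; beyond the scatter), concerns the exchange of a halogen for an aryl group and does not separate two aryl groups from each other, so no measured step bears directly on the change from compound 2 to compound 3. The expected step is a number no higher from compound 2 to compound 3 (the limit leaves the size open), no movement beyond the scatter. Compound 3 is accordingly estimated at 50000 nM, within a range of 15000 nM to 120000 nM, and is likely to be reported again only as a limit.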

Compound 3, half-maximal cytotoxic concentration: 27000 nM
Compound 3: the middle estimate sits 1.9-fold (0.27 log units) above what was measured; the measured number falls inside the stated range.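

In this assay this position on an aromatic carbon now has an aryl group with a measured number and not only a limit: 1-benzofuran-2-yl in place of iodo gives a 3.3-fold higher number from compound 1 to compound 3 (0.52 log units; beyond the scatter), and both aryl groups shown stand higher than iodo. The exchange of one aryl group for the other gives an at least 1.8-fold lower number from compound 2 to compound 3 (0.26 log units; that floor lies within the scatter), which does not establish a difference between thiophen-2-yl and 1-benzofuran-2-yl beyond the scatter. The true size of that step stays open because the value for compound 2 is a limit of the assay and not a number: the limit of > 50000 nM in this assay, at which 1 of the 3 values shown sits.

On these data alone, whether the higher tolerated concentration requires an aromatic ring at this position remains open, as an alkyl chain, an amine or a carboxylic acid here would show. Also open is how a plain phenyl ring would compare with the two aryl groups shown.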